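The source may report more compounds than this note shows. Statements on the series, on what has been measured and on what is new or still open speak of the compounds shown alone.

Compound 1 `CCc1c(OC)nc2nc(-c3nc(C)cs3)cn2c1C` is the only one of the three measured compounds that gives a number in a functional assay on the whole organism for antagonist activity, with Rattus norvegicus as the target, at a dose of 10 mg/kg by the oral route; a higher number here means that more compound is needed for the effect, a lower number that less compound is needed: compound 1 gives 10 mg/kg. Compound 2 `CCc1c(OC)nc2nc(-c3nc(C)c(C)s3)cn2c1C`, with methyl in place of hydrogen on an aromatic carbon, reaches only a limit of this assay, > 50 mg/kg. Compound 3 `CCc1c(OC)nc2nc(-c3nc(C(F)(F)F)cs3)cn2c1C`, with trifluoromethyl in place of methyl on an aromatic carbon, likewise gives only a limit, > 50 mg/kg. The two measured steps, an at least 5.0-fold higher number from compound 1 to compound 2 (0.69 log units; beyond the scatter) and an at least 5.0-fold higher number from compound 1 to compound 3 (0.69 log units; beyond the scatter), both concern aromatic carbons, and both end at the limit of > 50 mg/kg in this assay, at which 2 of the 3 values shown sit. Compound 4 `C=CCc1c(OC)nc2nc(-c3nc(C)cs3)cn2c1C` differs from compound 1 by vinyl in place of methyl on a saturated chain carbon bound to an aromatic carbon. Neither measured step touches this chain, so nothing beyond the scatter is expected. The step is estimated as no change at the digits printed from compound 1 to compound 4 (within the scatter). Compound 4 is therefore expected to give about 10 mg/kg, between 3 mg/kg and 30 mg/kg.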

Compound 4, minimum effective dose: > 50 mg/kg
Compound 4 gave a limit, no number (the forecaster's own chance of this, stated with the estimate: 25%); middle value at least 5.0-fold (0.69 log units) from the limit.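

The chain that neither earlier step touched is not free to change: going from ethyl to allyl on the aromatic carbon gives an at least 5.0-fold higher number from compound 1 to compound 4 (0.69 log units; beyond the scatter). The result shows that this assay responds to a change on this saturated chain carbon, and not only to changes on aromatic carbons. Every change from compound 1 shown here now ends at the same limit: the limit of > 50 mg/kg in this assay, at which 3 of the 4 values shown sit.

From the compounds shown here alone, whether a saturated propyl chain, or a methyl in place of the ethyl, keeps a number stays open. So does the true size of this step, which ends in a limit.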